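Thiol to methylthio on the carbocyclic nucleoside core

The source may hold more compounds than are shown below. What is called first, only, known or untested is meant among the compounds shown, and "the series" means these compounds.

Measured so far:
compound 1 `Nc1nc(O)c2nnn(C3CC(CO)C(O)C3O)c2n1`: > 100 ug/mL
compound 2 `Nc1nc(S)c2ncn(C3CC(CO)C(O)C3O)c2n1`: 50 ug/mL

In a functional assay on cells (Cancer cell lines, Homo sapiens) for cytotoxicity (a lower number here means that less compound is needed, a higher number that more compound is needed for the effect), compound 1 reaches only the limit of the assay, > 100 ug/mL (the limit of > 100 ug/mL in this assay, at which 1 of the 2 values shown sits). Among the compounds with values here, compound 2 gives the only actual number of the pair, 50 ug/mL in this assay. Compound 3 `CSc1nc(N)nc2c1ncn2C1CC(CO)C(O)C1O` differs from compound 2 by methyl in place of hydrogen on a sulfur. Within the data shown here, no step between measured compounds is available to scale this change, so the expected step of a 1.2-fold higher number from compound 2 to compound 3 (0.08 log units; within the scatter) is put at none beyond the scatter, with the weaker side left open. Compound 3 is therefore estimated at 60 ug/mL, expected within 20 ug/mL to 150 ug/mL in this assay.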

Compound 3, concentration for half-maximal effect: > 100 ug/mL
Compound 3: a limit, no number; the forecaster's own chance of this, stated with the estimate: 35%; middle value at least 1.6-fold (0.22 log units) from the limit.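

Methyl in place of hydrogen on a sulfur can now be read at this position: in this assay the change gives an at least 2.0-fold higher number from compound 2 to compound 3 (0.30 log units; that floor lies within the scatter). Compound 3 gives only a limit, > 100 ug/mL, so the step has a floor but no upper end. Only compound 2 still gives an actual number, and the others sit at the limit: the limit of > 100 ug/mL in this assay, at which 2 of the 3 values shown sit.

Open, on these data alone, is how far compound 3 lies from compound 2, and whether a longer chain on the sulfur or an amine in place of sulfanyl would give a number.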